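Chain extension from compound 2 to compound 3

The source may report more compounds than this note shows. Statements on the series, on what has been measured and on what is new or still open speak of the compounds shown alone.

Measured so far in a functional assay on A-431 cells (Homo sapiens) for antiproliferative activity, read by MTT assay, with a stated time of 72 h; a higher number here means a weaker inhibitor, a lower number a stronger inhibitor
- compound 1 `C=CC(=O)Nc1cc2c(Nc3cccc(Cl)c3F)ncnc2cc1OCc1cn(CCCCC(=O)NO)nn1` gives 15600 nM
- compound 2 `C=CC(=O)Nc1cc2c(Nc3ccc(F)c(Cl)c3)ncnc2cc1OCc1cn(CCCC(=O)NO)nn1` gives 20700 nM

Compound 2, at 20700 nM, lies within the scatter of compound 1 at 15600 nM, so these two numbers give no order. Both sit in the same high range of this assay and offer a single level to work from.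

Next in the series is compound 3 `C=CC(=O)Nc1cc2c(Nc3ccc(F)c(Cl)c3)ncnc2cc1OCc1cn(CCCCC(=O)NO)nn1`, not yet measured. Its difference from compound 2 is (hydroxycarbamoyl)methyl in place of hydroxycarbamoyl on a saturated chain carbon, three bonds along the chain from an aromatic nitrogen, which is (hydroxycarbamoyl)methyl in place of hydroxycarbamoyl on a saturated chain carbon, three bonds along the chain from an aromatic nitrogen. Cut further out, the same change reads 3-(hydroxycarbamoyl)propyl to 4-(hydroxycarbamoyl)butyl.

Within the data shown here, no measured pair yet isolates a change of this kind, so no direction can be argued, and no shift beyond the scatter is expected. The expectation rests on compound 2 at 20700 nM as its anchor. The estimated change is a 1.2-fold lower number from compound 2 to compound 3 (0.06 log units; within the scatter) and remains a small one. For compound 3 the estimated value is 18000 nM, with an expected range from 8000 nM to 40000 nM as its bounds.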

Compound 3, half-maximal inhibitory concentration: 15000 nM
Beside the measured number, compound 3's estimate is 1.2-fold (0.08 log units) above it, and the stated range covers the measured number.
By their numbers in this assay, from the lowest: compounds 3, 1 and 2 (each within the scatter of the next).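

In this assay, the change from 3-(hydroxycarbamoyl)propyl to 4-(hydroxycarbamoyl)butyl, on a saturated chain carbon three bonds along the chain from an aromatic nitrogen, gives a 1.4-fold lower number from compound 2 to compound 3 (0.14 log units; within the scatter) and so does not separate the two compounds. Among these compounds, this is the first measured pair to isolate this chain change, and at this pair of chains the assay does not register it. A second single change, 3-chloro-4-fluorophenyl in place of 3-chloro-2-fluorophenyl on a nitrogen on an aromatic ring, gives a 1.0-fold lower number from compound 1 to compound 3 (0.02 log units; within the scatter) and likewise leaves the two compounds unseparated, with no evidence available that bears on either step.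

The compounds shown span only two chains and two aryl groups, so it remains open whether a longer chain such as 6-(hydroxycarbamoyl)hexyl would move the number beyond the scatter. Among the compounds shown here, also open is what a carboxylic acid in place of the hydroxycarbamoyl end would do on the 4-(hydroxycarbamoyl)butyl chain, since no step so far shows this assay responding to any change.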